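A Naphthalen-1-yl Arm on a Shared Sulfonamide Core

The source may report more compounds than this note shows. Statements on the series, on what has been measured and on what is new or still open speak of the compounds shown alone.

Three sulfonamides share one core and differ only in the aryl group on a saturated chain carbon bound to an amine nitrogen. In a functional assay on BE(2)-C cells (Homo sapiens) for inhibition, read by MTT assay, with a stated time of 72 h (on this read-out higher numbers stand for weaker inhibition of growth and lower numbers for stronger inhibition of growth), compound 1 `COc1ccc(CNCCCNS(=O)(=O)c2cc(C(F)(F)F)cc(C(F)(F)F)c2)cc1OC` gives 3600 nM, compound 2 `O=S(=O)(NCCCNCc1ccc(Cl)c(C(F)(F)F)c1)c1cc(C(F)(F)F)cc(C(F)(F)F)c1` gives 8600 nM, and compound 3 `O=S(=O)(NCCCNCc1ccc(Br)cc1)c1cc(C(F)(F)F)cc(C(F)(F)F)c1` gives 2700 nM, the lowest of the three numbers. The step of a 1.3-fold lower number from compound 1 to compound 3 (0.12 log units; within the scatter) lies within the scatter, whereas a 3.2-fold lower number from compound 2 to compound 3 (0.50 log units; beyond the scatter) and a 2.4-fold higher number from compound 1 to compound 2 (0.38 log units; beyond the scatter) lie beyond it. Compound 4 `O=S(=O)(NCCCNCc1cccc2ccccc12)c1cc(C(F)(F)F)cc(C(F)(F)F)c1` carries naphthalen-1-yl in place of 4-bromophenyl on a saturated chain carbon bound to an amine nitrogen. Among the measured compounds shown here, no measured step introduces the naphthalen-1-yl group, so the three aryl swaps, which together span only a modest range, are the sole guide. A step of a 1.5-fold higher number from compound 3 to compound 4 (0.17 log units; within the scatter) is therefore expected. Compound 4 is estimated at 4000 nM in this assay, expected to fall between 1500 nM and 12000 nM.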

Compound 4, concentration for 50% growth inhibition: 2700 nM
Compound 4: the middle estimate sits 1.5-fold (0.17 log units) above what was measured; low and high end bracket the measured number.
By their numbers in this assay, from the lowest: compounds 3, 4 and 1 (each within the scatter of the next); then compound 2.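

In this assay, a second six-membered aromatic ring of carbon only, with no bromine, is accommodated on the saturated chain carbon bound to an amine nitrogen (no change at the digits printed from compound 3 to compound 4 (within the scatter)). Compound 4 also matches the 3,4-dimethoxyphenyl analogue (a 1.3-fold lower number from compound 1 to compound 4 (0.12 log units; within the scatter)), while the gap to the 4-chloro-3-(trifluoromethyl)phenyl analogue persists (a 3.2-fold lower number from compound 2 to compound 4 (0.50 log units; beyond the scatter)). No evidence is available on why these aryl groups read alike. On these data alone, whether naphthalen-2-yl or a pyridine ring would read the same at this position remains open. So does the effect of a longer chain in the shared core.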